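The compounds below may be only part of what the source reports. "The series", "measured", "known", "first", "only" and "open" are said of these compounds alone.

Measured compounds in the series:
- compound 1, `CS(=O)(=O)c1ccc(Cc2nnc3n2N=C(c2ccccc2)CS3)cc1`: 51%
- compound 2, `CS(=O)(=O)c1ccc(Cc2nnc3n2N=C(c2cc(Cl)sc2S(N)(=O)=O)CS3)cc1`: 18.7%
- compound 3, `CS(=O)(=O)c1ccc(Cc2nnc3n2N=C(c2cc(Cl)sc2Cl)CS3)cc1`: "not active" (no number reported)

In a functional assay on HT-29 cells (Homo sapiens) for cytotoxicity, read by MTT assay, with a stated time of 48 h, tested at 25 uM (on this read-out higher numbers stand for a stronger effect at the one concentration tested and lower numbers for a weaker effect), compound 1 gives 51%. Where compound 1 carries phenyl, compound 2 carries 5-chloro-2-sulfamoylthiophen-3-yl, and in this assay compound 2 gives 18.7%; the step of a number 32.3 percentage points lower from compound 1 to compound 2 (beyond the scatter) is the only one beyond the scatter among the measured pairs. Compound 3 stands apart: in this assay it is reported as "not active" (no number reported), with no number attached, so it cannot be placed on the same scale as compounds 1 and 2 beyond noting that it sits at or below the weak end of the series.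

Compound 4, `CS(=O)(=O)c1ccc(Cc2nnc3n2N=C(c2ccc(Cl)cc2Cl)CS3)cc1`, differs from compound 3 in one place: 2,4-dichlorophenyl in place of 2,5-dichlorothiophen-3-yl on a carbon with a double bond to nitrogen. The change removes the five-membered ring that both weak compounds 2 and 3 share and brings back a six-membered carbon ring of the kind found in compound 1, though now with two chlorines. Among the measured compounds shown here, the step from compound 1 to compound 2 shows that replacing phenyl at this position with a substituted thiophene costs a large amount of activity; no measured pair shows what chlorines on the phenyl itself do. The expectation is therefore an increase from compound 3 toward, but not reaching, compound 1. Compound 4 is estimated at 30%, within 5% to 55%.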

Compound 4, a percentage reported as activity, at one concentration (the size of the read-out at that concentration, not a potency): 24.2%
Beside the measured number, compound 4's estimate is 5.8 percentage points above it; low and high end bracket the measured number.
By their numbers in this assay, from the lowest: compounds 2 and 4 (each within the scatter of the next); then compound 1.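

In this assay, the change from phenyl to 2,4-dichlorophenyl gives a number 26.8 percentage points lower from compound 1 to compound 4 (beyond the scatter), so at this position, on a carbon with a double bond to nitrogen, the loss is not confined to the thiophene groups: a six-membered aromatic ring of carbon only, carrying two chlorines, also falls well short of the unsubstituted phenyl of compound 1. The 2,4-dichlorophenyl and 5-chloro-2-sulfamoylthiophen-3-yl groups are not separated by this read-out, with a number 5.5 percentage points higher from compound 2 to compound 4 (within the scatter), so among the numbered compounds, every substituted ring tested here stands apart from phenyl, whether it is five- or six-membered. The step between compound 3 and compound 4 cannot be read, as compound 3 carries a report of no activity and no number.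

No measurement on hand accounts for the loss with the substituted rings. Open, on these data alone, are the separate contributions of the two chlorines on the phenyl, and whether a single chlorine, a methoxy group, an amine or a carboxylic acid on that ring would hold the level of compound 1.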